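Swapping the ester for an acid in a styrylsulfone series

The source may report more compounds than this note shows. Statements on the series, on what has been measured and on what is new or still open speak of the compounds shown alone.

In a functional assay on DU-145 cells (Homo sapiens) for cytotoxicity, read by trypan blue exclusion, with a stated time of 96 h (a higher number here means a weaker inhibitor, a lower number a stronger inhibitor), compound 1 `COc1cc(OC)c(/C=C/S(=O)(=O)Cc2cc(N)ccc2OC)c(OC)c1` gives 7500 nM.
In this assay compound 2 `COC(=O)C(Nc1cc(CS(=O)(=O)/C=C/c2c(OC)cc(OC)cc2OC)ccc1OC)c1ccccc1` gives 75 nM.
In this assay compound 3 `COC(=O)C(Nc1cc(CS(=O)(=O)/C=C/c2c(OC)cc(OC)cc2OC)ccc1OC)c1ccc(OC)cc1` gives 250 nM.

Compound 2 has the lowest number of the three, so it is the strongest inhibitor measured so far; compound 3 sits nearest to it, and compound 1, which carries only a bare amino group where the others carry a substituted amine, sits far above it. Compound 4 `COc1cc(OC)c(/C=C/S(=O)(=O)Cc2ccc(OC)c(NC(C(=O)O)c3ccc(Cl)cc3)c2)c(OC)c1` has not yet been measured. It differs from compound 2 in one place: carboxy(4-chlorophenyl)methyl in place of methoxycarbonyl)(benzyl on a nitrogen on an aromatic ring. The side chain keeps its size, but the ester becomes a free carboxylic acid and the benzene ring gains a chlorine.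

Among the measured compounds shown here, only one measured step touches this side chain: a 3.3-fold higher number from compound 2 to compound 3 (0.52 log units; beyond the scatter), where a single methoxy on the benzene ring already made a modest difference. For the measured compounds named here, no measured pair shows the ester-to-acid change itself, so that part of the step is uncharted. A modest weakening beyond the scatter is therefore expected in this assay, of roughly a 2.7-fold higher number from compound 2 to compound 4 (0.43 log units; beyond the scatter). Compound 4 is estimated at 200 nM, with a range from 50 nM to 800 nM.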

Compound 4, half-maximal inhibitory concentration: 400 nM
For compound 4 the middle estimate is 2.0-fold (0.30 log units) below the measured one, within the range that was stated.
By their numbers in this assay, from the lowest: compound 2; then compounds 3 and 4 (each within the scatter of the next); then compound 1.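

The nitrogen on the aromatic ring accepts carboxy(4-chlorophenyl)methyl and the compound still keeps much of its activity, though the swap gives a 5.3-fold higher number from compound 2 to compound 4 (0.73 log units; beyond the scatter). In this assay compound 4 gives 400 nM, which remains far closer to the substituted amines than to compound 1 at 7500 nM, so a free carboxylic acid on this side chain does not return the number to that of the bare amino group. The step carries two changes at once, ester to acid and hydrogen to chlorine on the benzene ring, so it can only be read as a whole, and nothing measured here explains why the number rises.

The compounds shown leave open how that step divides: a free carboxylic acid with an unsubstituted benzene ring, or a methyl ester with a 4-chlorophenyl ring, would separate the two changes. They also leave open how a primary amide in place of the ester, or a fluorine in place of the chlorine, would read in this assay.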